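Working notes: hydroxy to nitro on the shared core

The source may hold more compounds than are shown below. What is called first, only, known or untested is meant among the compounds shown, and "the series" means these compounds.

Measured so far in a functional assay on Jurkat cells (Homo sapiens) for antiproliferative activity, read by WST assay, with a stated time of 72 h; on this read-out higher numbers stand for weaker inhibition and lower numbers for stronger inhibition:
compound 1 `COc1ccc2[nH]c(-c3nc(-c4ccccc4)no3)cc2c1`; compound 1 gives > 50000 nM, which is a limit of the assay.
compound 2 `Oc1ccc2[nH]c(-c3nc(-c4ccccc4)no3)cc2c1`; compound 2 gives 26900 nM.

Going by the values given here, compound 2 thus holds the only actual number in this assay; the other value shown is a limit (the limit of > 50000 nM in this assay, at which 1 of the 2 values shown sits). Among the compounds with values here, the single measured step, an at least 1.8-fold lower number from compound 1 to compound 2 (0.26 log units; that floor lies within the scatter), exchanged methyl for hydrogen on an oxygen on the aromatic ring, and its floor lies within the scatter, so it sets no firm direction.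

Compound 3 `O=[N+]([O-])c1ccc2[nH]c(-c3nc(-c4ccccc4)no3)cc2c1` differs from compound 2 by nitro in place of hydroxy on an aromatic carbon. Within the data shown here, no measured step exchanges hydroxy for nitro, and the one step available concerns the oxygen substituent only, so it bears on this change only loosely. The step from compound 2 to compound 3 in this assay is therefore estimated as a 1.1-fold higher number from compound 2 to compound 3 (0.05 log units; within the scatter), not clearly beyond the scatter, with wide uncertainty. Compound 3 is expected at 30000 nM, with a range from 8000 nM to 50000 nM.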

Compound 3, half-maximal inhibitory concentration: > 50000 nM
Compound 3 ended at the assay's limit; the forecaster's own chance of this, stated with the estimate: 40%; middle value at least 1.6-fold (0.22 log units) away from the limit.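

Compound 3 gives > 50000 nM in this assay, which is a limit of the assay. Nitro in place of hydroxy on this aromatic carbon gives an at least 1.8-fold higher number from compound 2 to compound 3 (0.26 log units; that floor lies within the scatter), so nitro, like methoxy, yields no actual number at this position, though the floor of the step does not clear the scatter. The step between the methoxy and nitro compounds cannot be read, and hydroxy remains the only group here with an actual number, which leaves little of the series open to comparison: the limit of > 50000 nM in this assay, at which 2 of the 3 values shown sit.

As far as these compounds go, the true standing of compound 1 and compound 3 relative to each other remains open. Also open, from the compounds shown here alone, is whether an amine or a carboxylic acid on the same aromatic carbon would give an actual number, and so whether hydroxy is exceptional at this position.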